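Aryl substituent change on the triazole of the shared core

The source may report more compounds than this note shows. Statements on the series, on what has been measured and on what is new or still open speak of the compounds shown alone.

Measured compounds:
- compound 1 `Cc1c(C(=O)Nc2ccc(Oc3ccnc4[nH]ccc34)c(F)c2)nnn1-c1ccccc1`: 290 nM
- compound 2 `COc1ccc(-n2nnc(C(=O)Nc3ccc(Oc4ccnc5[nH]ccc45)c(F)c3)c2C)cc1`: 590 nM

Compound 2 gives the highest of the two numbers in a functional assay on HT-29 cells (Homo sapiens) for cytotoxicity, read by MTT assay, with a stated time of 72 h; on this read-out lower numbers stand for stronger inhibition and higher numbers for weaker inhibition. For the measured compounds named here, its nearest neighbour is compound 1, and the step of a 2.0-fold higher number from compound 1 to compound 2 (0.31 log units; beyond the scatter) is the only measured step.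

Compound 3 `Cc1c(C(=O)Nc2ccc(Oc3ccnc4[nH]ccc34)c(F)c2)nnn1-c1ccc(F)c(Cl)c1` is not yet measured. Relative to compound 2 the change is 3-chloro-4-fluorophenyl in place of 4-methoxyphenyl on an aromatic nitrogen.

Going by the values given here, the one measured step, a 2.0-fold higher number from compound 1 to compound 2 (0.31 log units; beyond the scatter), bears on this only indirectly: it shows that adding a methoxy on the aromatic carbon of that phenyl ring moves the number up, modestly but beyond the scatter. Among the compounds with values here, compound 3 removes that methoxy again and carries 3-chloro-4-fluorophenyl instead; no measured compound carries this group, so its own effect is unknown. Taking the loss of the methoxy as the part that can be judged, the number for compound 3 is expected to fall back toward the level of compound 1, the estimated step being a 2.4-fold lower number from compound 2 to compound 3 (0.37 log units; beyond the scatter).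

The estimate for compound 3 in this assay is 250 nM, with a range from 70 nM to 900 nM.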

Compound 3, half-maximal inhibitory concentration: 1060 nM
Compound 3: middle estimate off by 4.2-fold (0.63 log units), on the low side, outside the stated range (above it).
By their numbers in this assay, from the lowest: compound 1; then compounds 2 and 3 (each within the scatter of the next).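

In this assay, the step of a 3.7-fold higher number from compound 1 to compound 3 (0.56 log units; beyond the scatter) shows that the effect of substitution on the phenyl ring at this aromatic nitrogen is not confined to the methoxy group, since a pair of halogens also leaves the number beyond the scatter of the one for plain phenyl. Exchanging one substituted ring for the other gives a 1.8-fold higher number from compound 2 to compound 3 (0.25 log units; within the scatter), so 4-methoxyphenyl and 3-chloro-4-fluorophenyl cannot be separated here, and among the three compounds both substituted rings stand apart from phenyl, with no compound shown going against this. Nothing measured explains why either substituted ring differs from phenyl at this position.

Still open, on these data alone, is whether the chlorine or the fluorine alone accounts for the step from phenyl, and whether an amine or a carboxylic acid on the phenyl ring, or a saturated ring in its place, would match or improve on compound 1 at 290 nM. All three compounds share the same methyl group and core, so it is also unknown whether this order of aryl groups holds when either of those changes.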